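The source may report more compounds than this note shows. Statements on the series, on what has been measured and on what is new or still open speak of the compounds shown alone.

The series shares one core and is read in a functional assay on OVCAR-4 cells (Homo sapiens) for cytotoxicity, read by sulforhodamine B assay, with a stated time of 48 h, tested at 100 nM; on this read-out higher numbers stand for a weaker effect at the one concentration tested and lower numbers for a stronger effect. Compound 1 `COc1cc(C)cc(-c2c(-c3ccnc(-c4ccc(C(C)=O)cc4)c3)cnn2CC#N)c1` gives 105% and so stands highest of the three numbers at hand. Compound 3 `Cc1cc(O)cc(-c2nn(CC#N)cc2-c2ccnc(-c3ccc(N(C)C)cc3)c2)c1` gives 101%, which lies within the scatter of compound 1. Compound 2 `COc1cc(C)cc(-c2nn(CC#N)cc2-c2ccc(-c3cccc(C(C)=O)c3)nc2)c1` gives 92%, a gap from compound 1 that lies beyond the scatter; compound 2 and compound 1 do not differ in one place alone, so nothing more is made of that pair.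

Compound 4 `COc1cc(C)cc(-c2c(-c3ccnc(-c4ccc(N(C)C)cc4)c3)cnn2CC#N)c1` has not yet been measured in this assay. It differs from compound 1 in one place: dimethylamino in place of acetyl on an aromatic carbon. Compound 3 already carries a dimethylamino group on the same kind of ring, and in this assay compound 3 gives 101%, close to what compound 1 gives. On that basis the step of a number 3 percentage points lower from compound 1 to compound 4 (within the scatter) is expected to be small and within the scatter, with no clear direction. Compound 4 is therefore expected to give about 102%, most likely between 88% and 115%.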

Compound 4, a percentage reported as activity, at one concentration (the size of the read-out at that concentration, not a potency): 33%
Beside the measured number, compound 4's estimate is 69 percentage points above it; measured number outside the range, below it.
By their numbers in this assay, from the lowest: compound 4; then compounds 2, 3 and 1 (each within the scatter of the next, the first and the last beyond it).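

In this assay, within the data shown here, dimethylamino in place of acetyl on this aromatic carbon gives a number 72 percentage points lower from compound 1 to compound 4 (beyond the scatter) and is the first change that can be read at a single place. It shows that this carbon, para to a large group, is not indifferent to what it carries, even though the two groups are equal in heavy atoms and neither has a ring or a net charge. Nothing measured here gives a reason for the change.

Compound 3 also carries dimethylamino and gives 101% yet differs from compound 4 in more than one place, so what separates these two stays unresolved. Also open, on these data alone, is whether a smaller primary amine, a cyclic amine such as pyrrolidine or a methoxy group on the same carbon would behave like dimethylamino.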